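The source may hold more compounds than are shown below. What is called first, only, known or untested is meant among the compounds shown, and "the series" means these compounds.

Compound 1 `O=[N+]([O-])c1ccc(CN2CCC(n3cc(CC(OCc4cc(-c5ccccc5)no4)c4ccc(Br)cc4)nn3)CC2)cc1` — in a functional assay on PC-3 cells (Homo sapiens) for cytotoxicity, with a stated time of 48 h (on this read-out higher numbers stand for weaker inhibition and lower numbers for stronger inhibition), compound 1 gives > 25000 nM, a limit of the assay (the limit of > 25000 nM in this assay, at which 1 of the 3 values shown sits).
Compound 2 `COc1ccc(-c2cc(COC(Cc3cn(C4CCN(Cc5ccc([N+](=O)[O-])cc5)CC4)nn3)c3ccc(Br)cc3)on2)cc1` — in this assay compound 2 gives 3000 nM.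
Compound 3 `N#Cc1ccc(-c2cc(COC(Cc3cn(C4CCN(Cc5ccc([N+](=O)[O-])cc5)CC4)nn3)c3ccc(Br)cc3)on2)cc1` — in this assay compound 3 gives 2000 nM.

Compound 3 stands at the lowest of the two numbers recorded, with compound 2 its nearest neighbour; the step of a 1.5-fold lower number from compound 2 to compound 3 (0.18 log units; within the scatter) lies within the scatter, so the two cannot be ordered. Both steps from the unsubstituted phenyl, an at least 8.3-fold lower number from compound 1 to compound 2 (0.92 log units; beyond the scatter) and an at least 12-fold lower number from compound 1 to compound 3 (1.09 log units; beyond the scatter), were beyond the scatter.

Compound 4 `O=[N+]([O-])c1ccc(CN2CCC(n3cc(CC(OCc4cc(-c5cccc(Br)c5)no4)c4ccc(Br)cc4)nn3)CC2)cc1` differs from compound 3 by 3-bromophenyl in place of 4-cyanophenyl on an aromatic carbon. Going by the values given here, no measured step covers a 3-bromophenyl here; the only steps that bear on it show that an unsubstituted phenyl in compound 1 reaches the limit, while methoxy or cyano on that ring gives a number. A bromine at a different ring position is therefore expected to fall between these outcomes, with a modest rise in the number in this assay and a real chance of a limit.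

For compound 4 the estimate in this assay is 5000 nM, within 1500 nM to 20000 nM, meaning an expected step of a 2.5-fold higher number from compound 3 to compound 4 (0.40 log units; beyond the scatter).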

Compound 4, half-maximal inhibitory concentration: > 25000 nM
Compound 4 gave a limit, no number (the forecaster's own chance of this, stated with the estimate: 25%); at least 5.0-fold (0.69 log units) between middle value and limit.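

Compound 4 shows that putting a substituent on this phenyl ring does not by itself give a number in this assay: the 3-bromophenyl falls away from the 4-cyanophenyl with an at least 12-fold higher number from compound 3 to compound 4 (1.09 log units; beyond the scatter) and from the 4-methoxyphenyl with an at least 8.3-fold higher number from compound 2 to compound 4 (0.92 log units; beyond the scatter). Compound 4 sits at a limit of the assay, as compound 1 does: the limit of > 25000 nM in this assay, at which 2 of the 4 values shown sit.
The step between these two limits cannot be read, so the bromo compound cannot be ranked against the unsubstituted phenyl.

Compound 4 changes both the substituent and where it sits on the ring, and the compounds shown do not separate these two changes, which a 4-bromophenyl would begin to do. From the compounds shown here alone, whether an amine or a carboxylic acid on this ring would give a number also stays open.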